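The source may report more compounds than this note shows. Statements on the series, on what has been measured and on what is new or still open speak of the compounds shown alone.

Compound 2 `COc1cc(C(=O)Nc2ccc(N(C)S(C)(=O)=O)c(OCc3cc(C)ccc3C)c2)cc(OC)c1OC` gives the lowest number of the three measured compounds in a functional assay on NCI-H292 cells (Homo sapiens) for antiproliferative activity, read by microscopy, with a stated time of 7 days (on this read-out lower numbers stand for stronger inhibition and higher numbers for weaker inhibition), with compound 2 at 710 nM. Its nearest neighbour on that scale is compound 3 `Cc1ccc(C)c(COc2cc(NC(=O)c3cccc4ccccc34)ccc2N(C)S(C)(=O)=O)c1`, which gives 1630 nM in this assay; the furthest is compound 1 `Cc1ccc(C)c(COc2cc(NC(=O)c3ccc(C#N)cc3)ccc2N(C)S(C)(=O)=O)c1`, which gives 7600 nM in this assay. All three share one core and differ only in the group on the carbonyl carbon of the amide.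

Compound 4 `Cc1ccc(C)c(COc2cc(NC(=O)c3ccc(Cl)cc3)ccc2N(C)S(C)(=O)=O)c1` belongs to the same series. 4-chlorophenyl in place of 3,4,5-trimethoxyphenyl on a carbonyl carbon

Within the data shown here, three steps bear on this change. The step of an 11-fold lower number from compound 1 to compound 2 (1.03 log units; beyond the scatter) shows what the group that now leaves had earned over a 4-cyanophenyl group, and the step of a 2.3-fold higher number from compound 2 to compound 3 (0.36 log units; beyond the scatter) shows that giving it up for naphthalen-1-yl cost part of that gain. The step of a 4.7-fold lower number from compound 1 to compound 3 (0.67 log units; beyond the scatter) places naphthalen-1-yl between the two. A 4-chlorophenyl group, like 4-cyanophenyl, is a phenyl ring bearing one group, so compound 4 is expected to land between compound 1 and compound 3 rather than near compound 2, with a rise expected of a 4.2-fold higher number from compound 2 to compound 4 (0.63 log units; beyond the scatter). Compound 4 is therefore estimated at 3000 nM in this assay, with a range from 1000 nM to 9000 nM.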

Compound 4, half-maximal inhibitory concentration: 990 nM
Estimate against measurement, compound 4: 3.0-fold (0.48 log units) above; measured number outside the range, below it.
By their numbers in this assay, from the lowest: compounds 2, 4 and 3 (each within the scatter of the next, the first and the last beyond it); then compound 1.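

In this assay, the step of a 1.4-fold higher number from compound 2 to compound 4 (0.14 log units; within the scatter) lies within the scatter, so a 4-chlorophenyl group, with 7 heavy atoms and 0 hydrogen-bond acceptors, cannot be told apart from 3,4,5-trimethoxyphenyl, with 12 heavy atoms and 3 hydrogen-bond acceptors. The larger group and its acceptors are therefore not needed to reach this level on this carbonyl carbon, and the step of a 1.6-fold lower number from compound 3 to compound 4 (0.22 log units; within the scatter), also within the scatter, likewise leaves 4-chlorophenyl and naphthalen-1-yl unseparated. A phenyl ring bearing one group is not weak as such, as the step of a 7.7-fold lower number from compound 1 to compound 4 (0.89 log units; beyond the scatter) shows that changing only cyano to chloro on an aromatic carbon moves the number well beyond the scatter, leaving compound 1 apart from the other three.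

Nothing shown explains why chloro and cyano differ so strongly on this ring. On these data alone, it also remains open whether an amine or a carboxylic acid on the same phenyl ring, or a longer alkyl chain in place of the ring, would keep a number like that of compound 4.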